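From Sulfonyl to Sulfanyl in a Growth-Inhibition Series

This account rests on a few compounds, and the source may have more. Where it says the series, first, only, none or still open, it means among the compounds named here.

Of the compounds shown here, two have been measured so far. In a functional assay on DU-145 cells (Homo sapiens) for inhibition, read by trypan blue exclusion, with a stated time of 96 h (a lower number here means a stronger inhibitor of growth, a higher number a weaker inhibitor of growth), compound 1 (`Cc1ccc(S(=O)(=O)/C(=C/c2c(F)c(F)c(F)c(F)c2F)C(=O)c2ccc(Cl)cc2)cc1`) is reported as a limit, > 100000 nM, and not as a number. Among the compounds with values here, compound 2 (`O=C(/C(=C\c1ccc(OCc2ccccc2)cc1)S(=O)(=O)Cc1ccc(Cl)cc1)c1ccc(Cl)cc1`) gives 1000 nM, the only actual number. Compound 3 (`O=C(/C(=C\c1ccc(OCc2ccccc2)cc1)SCc1ccc(Cl)cc1Cl)c1ccc(Cl)cc1`) departs from compound 2 at one place: (2,4-dichlorobenzyl)sulfanyl in place of (4-chlorobenzyl)sulfonyl on a double-bonded chain carbon bound to a carbonyl carbon and a double-bonded chain carbon. It carries (2,4-dichlorobenzyl)sulfanyl in place of (4-chlorobenzyl)sulfonyl on a double-bonded chain carbon bound to a carbonyl carbon and a double-bonded chain carbon. Within the data shown here, no measured pair shows what such a change does in this assay, and the expectation therefore stays loose, anchored only on compound 2 at 1000 nM. A weaker inhibitor of growth is expected, with an estimated change of a 5.0-fold higher number from compound 2 to compound 3 (0.70 log units; beyond the scatter), beyond the usual scatter. For compound 3 the expected value is 5000 nM, with an estimated range of 800 nM to 40000 nM.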

Compound 3, concentration for 50% growth inhibition: 1000 nM
Estimate against measurement, compound 3: 5.0-fold (0.70 log units) above, and the stated range covers the measured number.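

Within the data shown here, the first readable step in this assay shows no change at the digits printed from compound 2 to compound 3 (within the scatter). At this double-bonded chain carbon bound to a carbonyl carbon and a double-bonded chain carbon, (2,4-dichlorobenzyl)sulfanyl therefore takes the place of (4-chlorobenzyl)sulfonyl with growth inhibition retained, so the oxygen atoms of the sulfonyl are not required for this level of inhibition in this pair. The step alters the sulfur and the chlorine pattern of the benzyl ring together, and a single pair cannot separate the two changes or show whether they offset each other.

The compounds shown leave open how (4-chlorobenzyl)sulfanyl, which would isolate the sulfur change, or a benzyl group carrying an amine would read at this place. Compound 1 remains a limit and not a number, so no step to it can be read: the limit of > 100000 nM in this assay, at which 1 of the 3 values shown sits.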